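Imidazopyridine ethers: dimethylphenyl for trifluoromethylphenyl

A few compounds are considered here, and "the series" means these few. Any claim that something is new, unique, unknown or untested is made for them only; others in the source may bear on it.

Working notes on the series. In an assay on isolated protein for agonist activity at Free fatty acid receptor 1 (Homo sapiens) (a lower number here means that less compound is needed, a higher number that more compound is needed for the effect), compound 1 `CC#CC(CC(=O)O)c1ccc(OCc2ccc3nc(-c4ccc(C(F)(F)F)cc4)cn3c2)cc1` gives 558 nM, the lower of the two numbers recorded so far. Compound 2 `CC#CC(CC(=O)O)c1ccc(OCc2ccn3cc(-c4ccccc4)nc3c2)cc1`, which carries a different fused core and an unsubstituted phenyl, gives 1260 nM in this assay, a gap that lies beyond the usual scatter of repeated measurements. Going by the values given here, no step between measured compounds that differ in one place has been recorded, so nothing in the set itself calibrates the effect of changing the aryl group on the core of compound 1.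

Compound 3 `CC#CC(CC(=O)O)c1ccc(OCc2ccc3nc(-c4ccc(C)cc4C)cn3c2)cc1` is the next candidate. Relative to compound 1 the change is 2,4-dimethylphenyl in place of 4-(trifluoromethyl)phenyl on an aromatic carbon. Among the compounds with values here, with no directly comparable pair to draw on, the step from compound 1 to compound 3 is expected to be small, with the number drifting upward if at all, and most likely not beyond the scatter; this expected step is a 1.3-fold higher number from compound 1 to compound 3 (0.13 log units; within the scatter). Compound 3 is therefore estimated at 750 nM in this assay, with a plausible range from 250 nM to 2200 nM.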

Compound 3, half-maximal effective concentration: 316 nM
Estimate against measurement, compound 3: 2.4-fold (0.38 log units) above; measured number inside the range.
By their numbers in this assay, from the lowest: compounds 3 and 1 (each within the scatter of the next); then compound 2.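

In this assay, going by these compounds alone, the step of a 1.8-fold lower number from compound 1 to compound 3 (0.25 log units; within the scatter) is the first comparison in the set between compounds that differ in one place, and it lies within the scatter. On this aromatic carbon of a five-membered aromatic ring with 2 nitrogen, next to the ring nitrogen, 2,4-dimethylphenyl and 4-(trifluoromethyl)phenyl cannot be told apart in this assay, even though the exchange removes all 3 fluorine atoms and replaces a group of 10 heavy atoms with one of 8, so this single pair gives no sign that the trifluoromethyl group is needed on the shared core. No measurement in the set bears on why these two aryl groups read alike.

The compounds shown leave open whether this position stays as undemanding with a pyridine ring in place of the phenyl, or with a phenyl carrying an amine or a carboxylic acid. They also leave open what each methyl group of the 2,4-dimethylphenyl contributes alone, and whether a single methoxy group on the phenyl would read any differently on this core.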